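Benzylsulfanyl in place of ethylsulfanyl on the uridine monophosphate core

This account rests on a few compounds, and the source may have more. Where it says the series, first, only, none or still open, it means among the compounds named here.

Measured so far:
compound 1, `CCSc1nc(=O)ccn1[C@@H]1O[C@H](COP(=O)(O)O)[C@@H](O)[C@H]1O`: > 100000 nM
compound 2, `COc1nc(=O)ccn1[C@@H]1O[C@H](COP(=O)(O)OP(=O)(O)O)[C@@H](O)[C@H]1O`: 1370 nM

Compound 1 was tested in an in vitro functional assay on 1321-N1 cells for agonist activity at P2Y purinoceptor 6 (Homo sapiens), read by scintillation proximity assay and inositol phosphate accumulation; on this read-out lower numbers stand for an effect already at smaller amounts and higher numbers for an effect only at larger amounts of compound. For compound 1 the result is a limit of the assay, not a number: > 100000 nM. It sits at the limit of > 100000 nM in this assay, at which 1 of the 2 values shown sits. Compound 2 carries a diphosphate and a methoxy group rather than the monophosphate and ethylsulfanyl of compound 1. In this assay compound 2 gives 1370 nM. Going by the values given here, the two measured compounds differ in more than one place, so no single step between them can be read off; only their two values stand side by side.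

The next compound is compound 3, `O=c1ccn([C@@H]2O[C@H](COP(=O)(O)O)[C@@H](O)[C@H]2O)c(SCc2ccccc2)n1`. It differs from compound 1 by phenyl in place of methyl on a saturated chain carbon bound to a sulfur. Among the compounds with values here, no measured pair shows what such a change does here. Since compound 1 only reaches a limit, the estimate for compound 3 rests on that limit alone and stays weak: compound 3 is expected to give 50000 nM, within 5000 nM to 300000 nM. The step from compound 1 to compound 3 is estimated as an at least 2.0-fold lower number from compound 1 to compound 3 (0.30 log units; that floor lies within the scatter), with a fair chance that the assay again reports only a limit.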

Compound 3, half-maximal effective concentration: > 100000 nM
Compound 3 gave a limit, no number (the forecaster's own chance of this, stated with the estimate: 55%); at least 2.0-fold (0.30 log units) between middle value and limit.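

Compound 1 and compound 3 both end at a limit of the assay rather than a number, so no step between them can be read: the limit of > 100000 nM in this assay, at which 2 of the 3 values shown sit.

The compounds shown leave open whether a sulfanyl group on the monophosphate core can give a measurable value, and whether the diphosphate or the methoxy group accounts for compound 2 reaching 1370 nM.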